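The compounds below may be only part of what the source reports. "The series", "measured", "known", "first", "only" and "open" are said of these compounds alone.

Compound 1, with the structure `CC(C)=CCC1Cc2c(O)cc(=O)n(CCCO)c2CC1(C)C`, is the starting point of this set. In a functional assay on PANC-1 cells (Homo sapiens) for inhibition, read by MTT assay, with a stated time of 24 h, tested at 10 uM (on this read-out lower numbers stand for less inhibition and higher numbers for more inhibition at the one concentration tested (going by the name of the read-out)), compound 1 gives 0%, and on that reading it stands level with the two other measured compounds at the digits reported. Compound 2, `COc1cccc(NC(=O)Oc2cc(=O)n(CCCO)c3c2CC(CC=C(C)C)C(C)(C)C3)c1`, carries a (3-methoxyphenyl)carbamoyl group on an oxygen on an aromatic ring where compound 1 carries hydrogen; in this assay compound 2 gives 0%. Compound 3, `CC(C)=CCC1Cc2c(OC(=O)Nc3ccc(F)c(F)c3)cc(=O)n(CCCO)c2CC1(C)C`, carries a (3,4-difluorophenyl)carbamoyl group on that oxygen; in this assay compound 3 gives 0%. The steps among them are no change at the digits printed from compound 1 to compound 2 (within the scatter), no change at the digits printed from compound 1 to compound 3 (within the scatter) and no change at the digits printed from compound 2 to compound 3 (within the scatter), each within the scatter.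

Compound 4, `CC(C)=CCC1Cc2c(OC(=O)Nc3ccc(Cl)cc3)cc(=O)n(CCCO)c2CC1(C)C`, differs from compound 1 by (4-chlorophenyl)carbamoyl in place of hydrogen on an oxygen on an aromatic ring. Both measured steps that put an aryl carbamoyl group on that same oxygen left the reading unchanged, and the exchange of one aryl group for another between compound 2 and compound 3 did the same. Among the measured compounds shown here, nothing among the measured compounds points to a shift in either direction. For compound 4 the expected step is therefore no change at the digits printed from compound 1 to compound 4 (within the scatter), none beyond the scatter. Compound 4 is estimated at 0% in this assay, with a range from -5% to 10%.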

Compound 4, a percentage reported as inhibition, at one concentration (the size of the read-out at that concentration, not a potency): 0%
Beside the measured number, compound 4's estimate shows no gap at the digits printed; the range from low to high includes it.
By their numbers in this assay, from the lowest: compounds 1, 2, 3 and 4 (each within the scatter of the next).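

With the third aryl carbamoyl group on an oxygen on an aromatic ring, this assay gives no change at the digits printed from compound 1 to compound 4 (within the scatter) for the (4-chlorophenyl)carbamoyl group in place of hydrogen, so a chlorine-bearing phenyl now joins the methoxy- and difluoro-substituted ones at this position without moving the reading. Exchanging the aryl group on the amide-type nitrogen also leaves the reading in place, with no change at the digits printed from compound 3 to compound 4 (within the scatter) for 4-chlorophenyl in place of 3,4-difluorophenyl and no change at the digits printed from compound 2 to compound 4 (within the scatter) for 4-chlorophenyl in place of 3-methoxyphenyl, and all four compounds therefore share one printed value. No measurement is available that would explain this flat result.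

The compounds shown leave open whether a carboxylic acid or an amine on the phenyl ring, or a longer chain between the carbamoyl group and that ring, would move the reading at this position. They also leave open how any of the four compounds behaves away from the one concentration tested, as a single reading at that concentration gives no potency.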